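A few compounds are considered here, and "the series" means these few. Any claim that something is new, unique, unknown or untested is made for them only; others in the source may bear on it.

Working notes on the series.

In a functional assay on HeLa cells (Homo sapiens) for cytotoxicity, read by MTT assay, with a stated time of 48 h (a higher number here means a weaker inhibitor, a lower number a stronger inhibitor), compound 3 `O=c1ccoc2cc(OCc3cn(Cc4ccccc4Cl)nn3)ccc12` gives only a limit, > 100000 nM. Compound 1 `Cc1cccc(Cn2cc(COc3ccc4c(=O)ccoc4c3)nn2)c1` likewise gives a limit in this assay, > 100000 nM. Compound 2 `Cc1ccc(Cn2cc(COc3ccc4c(=O)ccoc4c3)nn2)cc1` also gives a limit in this assay, > 100000 nM. So compound 3 stands at the same limit as every other value shown, which is what the limit of > 100000 nM in this assay, at which 3 of the 3 values shown sit, records.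

Compound 4 `O=c1ccoc2cc(OCc3cn(Cc4ccc(Cl)cc4)nn3)ccc12` differs from compound 3 by 4-chlorophenyl in place of 2-chlorophenyl on a saturated chain carbon bound to an aromatic nitrogen. The measured steps that bear on a change of the group on the saturated chain carbon bound to an aromatic nitrogen are a step that the two limits leave unreadable from compound 1 to compound 2, a step that the two limits leave unreadable from compound 1 to compound 3 and a step that the two limits leave unreadable from compound 2 to compound 3; none of them is readable, since both ends of each sit at the limit. Within the data shown here, no step in this assay has therefore been seen to move any compound off the limit.

The step that the limit leaves unreadable from compound 3 to compound 4 is accordingly estimated to be none beyond the scatter, and compound 4 is expected to give about 150000 nM in this assay, between 40000 nM and 500000 nM, most probably reported as a limit again.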

Compound 4, half-maximal inhibitory concentration: 37600 nM
Beside the measured number, compound 4's estimate is 4.0-fold (0.60 log units) above it; the measured number lies below the stated range.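

In this assay, the place on a saturated chain carbon bound to an aromatic nitrogen now gives its first readable result: 4-chlorophenyl in place of 2-chlorophenyl, with the same atoms joined differently, gives an at least 2.6-fold lower number from compound 3 to compound 4 (0.42 log units; beyond the scatter). Chloro in place of methyl on an aromatic carbon gives an at least 2.6-fold lower number from compound 2 to compound 4 (0.42 log units; beyond the scatter), and 4-chlorophenyl in place of 3-methylphenyl gives an at least 2.6-fold lower number from compound 1 to compound 4 (0.42 log units; beyond the scatter). Among the compounds shown, only compound 4 has left the limit, so these steps give minimum sizes only, and the steps among the other three remain unreadable: the limit of > 100000 nM in this assay, at which 3 of the 4 values shown sit.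

From the compounds shown here alone, whether a bromo or a methoxy group in place of the chloro of compound 4 would give a lower number remains open. So does whether the 4-chlorophenyl result depends on the chloro itself, as the 3-methylphenyl and 4-methylphenyl compounds stay at the limit.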